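The compounds below may be only part of what the source reports. "The series", "measured", "known", "first", "only" and "open" are said of these compounds alone.

Compound 2 `COc1cc(/C=C/C(=O)c2cccc(-n3cc(-c4ccccc4)[nH]c3=O)c2)ccc1O` stands at the lowest of the two numbers recorded so far in a functional assay on RPMI8266 cells (Homo sapiens) for inhibition; on this read-out higher numbers stand for weaker inhibition of growth and lower numbers for stronger inhibition of growth: compound 2 gives 1670 nM, while compound 1 `COc1cc(/C=C/C(=O)c2cccc(-n3cc(-c4ccc(Cl)cc4)[nH]c3=O)c2)cc(OC)c1OC` gives 3920 nM, a gap beyond the usual scatter. Compound 3 `O=C(/C=C/c1cccc(O)c1)c1cccc(-n2cc(-c3ccccc3)[nH]c2=O)c1` differs from compound 2 by 3-hydroxyphenyl in place of 4-hydroxy-3-methoxyphenyl on a double-bonded chain carbon bound to a double-bonded chain carbon. Going by the values given here, no earlier pair of measured compounds shows the effect of this kind of change, so its direction is uncertain; a step that is expected to be small, and probably toward weaker inhibition, is a 1.5-fold higher number from compound 2 to compound 3 (0.18 log units; within the scatter). Compound 3 is therefore estimated at 2500 nM, within a range from 900 nM to 7000 nM.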

Compound 3, concentration for 50% growth inhibition: 2150 nM
For compound 3 the middle estimate is 1.2-fold (0.07 log units) above the measured one; measured number inside the range.
By their numbers in this assay, from the lowest: compounds 2, 3 and 1 (each within the scatter of the next, the first and the last beyond it).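

In this assay, 3-hydroxyphenyl in place of 4-hydroxy-3-methoxyphenyl gives a 1.3-fold higher number from compound 2 to compound 3 (0.11 log units; within the scatter) at this position on the chain. This first one-place comparison shows that the two groups cannot be told apart here, even though the entering group is smaller by the methoxy group. Nothing available bears on a reason for this result.

Still open, from the compounds shown here alone, is whether a plain phenyl, or a ring carrying an amine or a carboxylic acid, would read differently here. Going by these compounds, the hydroxy group's own contribution also remains unknown, since both compounds carry one.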